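Aryloxy exchange on the shared core: compound 1 toward compound 4

The compounds below may be only part of what the source reports. "The series", "measured", "known", "first", "only" and "open" are said of these compounds alone.

Measured in a functional assay on NCI-H522 cells (Homo sapiens) for inhibition, read by sulforhodamine B assay, with a stated time of 48 h; on this read-out higher numbers stand for lower toxicity in this test and lower numbers for higher toxicity in this test:
compound 1 `Nc1cc(N)c2nc(-c3ccccc3)c(Oc3ccc(Cl)c(Cl)c3)nc2c1` gives < 100000 nM, a limit of the assay.
compound 2 `CCOC(=O)[C@H](CCC(=O)O)NC(=O)c1ccc(CNc2nc3cc(N)cc(N)c3nc2-c2ccccc2)cc1` gives < 100000 nM, also a limit.
compound 3 `COc1cc(CNc2nc3cc(N)cc(N)c3nc2-c2ccccc2)cc(OC)c1OC` gives < 50200 nM, a limit as well.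

None of the three readings is a number; each is a limit. Compound 1 stands at the limit of < 100000 nM in this assay, at which 2 of the 3 values shown sit, together with compound 2, while compound 3 sits at the limit of < 50200 nM in this assay, at which 1 of the 3 values shown sits. On these readings compound 1 cannot be ranked against compound 2 or compound 3. Among the measured compounds shown here, no pair among the measured compounds differs in one place, so no measured step is available.

Compound 4 `Nc1cc(N)c2nc(-c3ccccc3)c(Oc3ccc(F)cc3)nc2c1` differs from compound 1 in one place: 4-fluorophenyl in place of 3,4-dichlorophenyl on an oxygen on an aromatic ring. For the measured compounds named here, with no measured step to lean on, no shift beyond the usual scatter is expected in this assay from this change. Compound 4 is expected to read 60000 nM in this assay, with a range of 20000 nM to 150000 nM. The expected step that the limit leaves unreadable from compound 1 to compound 4 amounts to no change beyond the scatter, and a limit rather than a number is judged the more likely outcome for compound 4.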

Compound 4, concentration lethal to 50% of the cells: < 100000 nM
Compound 4 ended at the assay's limit (the forecaster's own chance of this, stated with the estimate: 75%); the middle value lies beyond the limit too.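

No step can be read from compound 1 to compound 4, since both readings are limits and not numbers: the limit of < 100000 nM in this assay, at which 3 of the 4 values shown sit.

The compounds shown leave open whether 4-fluorophenyl and 3,4-dichlorophenyl on the shared core differ at all in this assay.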